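Replacing trifluoromethyl with methoxy in compound 2

The compounds below may be only part of what the source reports. "The series", "measured", "known", "first", "only" and "open" are said of these compounds alone.

Compound 1 `C/C(=N\NC(N)=S)c1ccc2[nH]c(-c3ccccc3)nc2c1` gives 32000 nM
Compound 2 `C/C(=N\NC(N)=S)c1ccc2[nH]c(-c3ccc(C(F)(F)F)cc3)nc2c1` gives 5000 nM

In an ADME assay on BHK-21 cells (Mesocricetus auratus) for cytotoxicity, read by MTT assay (a higher number here means that more compound is tolerated, a lower number that less compound is tolerated), compound 2 holds the lower of the two numbers at 5000 nM, and compound 1 gives 32000 nM. Compound 3 `COc1ccc(-c2nc3cc(/C(C)=N/NC(N)=S)ccc3[nH]2)cc1` has not yet been measured. It differs from compound 2 by methoxy in place of trifluoromethyl on an aromatic carbon, para to a large group: methoxy in place of trifluoromethyl on an aromatic carbon. Among the measured compounds shown here, one measured step bears on this change: a 6.4-fold lower number from compound 1 to compound 2 (0.81 log units; beyond the scatter), a modest step beyond the scatter, in which trifluoromethyl replaced hydrogen on an aromatic carbon. For the measured compounds named here, no measured step involves methoxy, so the expectation rests on that step alone, and part of it may be reversed once trifluoromethyl leaves. A modest rise in this assay is therefore expected, a 2.8-fold higher number from compound 2 to compound 3 (0.45 log units; beyond the scatter). For compound 3 the estimated value is 14000 nM, with an expected range of 5000 nM to 40000 nM.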

Compound 3, half-maximal cytotoxic concentration: 13000 nM
The estimate for compound 3 lay 1.1-fold (0.03 log units) above the measured number; low and high end bracket the measured number.
By their numbers in this assay, from the lowest: compound 2; then compound 3; then compound 1.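

In this assay, moving from trifluoromethyl to methoxy on this aromatic carbon, para to a large group, gives a 2.6-fold higher number from compound 2 to compound 3 (0.41 log units; beyond the scatter) and so recovers part of the drop that trifluoromethyl brought. Methoxy does not restore the level of the unsubstituted compound, however, as there is a 2.5-fold lower number from compound 1 to compound 3 (0.39 log units; beyond the scatter) and thus both substituents shown lower the number relative to hydrogen, trifluoromethyl by more. The data shown offer no measurement that explains this order of hydrogen, methoxy and trifluoromethyl.

From the compounds shown here alone, it remains open whether an amine, a carboxylic acid or a longer chain such as ethoxy at this carbon would fit within the range set by these three compounds. Going by these compounds, it is also open whether the same order would hold for these groups at another position on the shared core.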